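The compounds below may be only part of what the source reports. "The series", "measured", "known", "first", "only" and "open" are said of these compounds alone.

Measured compounds:
Compound 1, `NC1=NC2(CCOCC2)N(OCCCOc2ccc(Cl)cc2)C(N)=N1`: 330 nM
Compound 2, `NC1=NC2(CCSCC2)N(OCCCOc2cccc(Br)c2)C(N)=N1`: 200 nM

In a functional assay on HL-60 cells (Homo sapiens) for antiproliferative activity, read by MTT assay, with a stated time of 72 h (a lower number here means a stronger inhibitor, a higher number a weaker inhibitor), compound 1 gives 330 nM, the higher of the two numbers shown, while compound 2 gives 200 nM; the gap between them lies within the scatter, so no order can be read from it. Compound 3, `NC1=NC2(CCOCC2)N(OCCCOc2ccc(Br)cc2)C(N)=N1`, has not been measured. Its difference from compound 1 is bromo in place of chloro on an aromatic carbon. Among the compounds with values here, no measured pair shows this change alone, so the expected step is small, and is estimated as a 1.2-fold lower number from compound 1 to compound 3 (0.07 log units; within the scatter), no more than the scatter. Compound 3 is therefore expected to give 280 nM, in the range 130 nM to 600 nM.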

Compound 3, half-maximal inhibitory concentration: 310 nM
For compound 3 the middle estimate is 1.1-fold (0.04 log units) below the measured one; the measured number falls inside the stated range.
By their numbers in this assay, from the lowest: compounds 2, 3 and 1 (each within the scatter of the next).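

Bromo in place of chloro on an aromatic carbon, para to a large group, gives in this assay a 1.1-fold lower number from compound 1 to compound 3 (0.03 log units; within the scatter) and so leaves the number unchanged within the scatter. Within the data shown here, this is the first comparison here that isolates a single change, which compounds 1 and 2 could not offer, and it shows that these two halogens cannot be told apart at this position. Nothing available explains this result. The compounds shown leave open whether an amine or a carboxylic acid at this position would give a different number. They also leave open what a longer chain would do.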